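Swapping the bicyclic headgroup on the amide carbonyl

The source may report more compounds than this note shows. Statements on the series, on what has been measured and on what is new or still open speak of the compounds shown alone.

Measured compounds:
compound 1 `O=C(NCc1ccc(S(=O)(=O)N2CCCCC2)cc1)c1cnc2nccn2c1` gives 3 nM in an assay for inhibition of Nicotinamide phosphoribosyltransferase (Homo sapiens), read by mass spectrometry, with stated times of 15 min and 30 min; on this read-out higher numbers stand for weaker inhibition and lower numbers for stronger inhibition;
compound 2 `O=C(NCc1ccc(S(=O)(=O)N2CCCCC2)cc1)c1cc2ccncc2o1` gives 40 nM in this assay.

Compound 2 stands highest of the two numbers, with compound 1 the nearest point, a 13-fold higher number from compound 1 to compound 2 (1.12 log units; beyond the scatter). Compound 3 `O=C(NCc1ccc(S(=O)(=O)N2CCCCC2)cc1)c1ccn2ccnc2c1` is the next compound to be measured. It differs from compound 2 in one place: a group of 9 heavy atoms (7 carbon, 2 nitrogen; one five-membered aromatic ring with 2 hetero atoms, one six-membered aromatic ring with 1 hetero atom) in place of a group of 9 heavy atoms (7 carbon, 1 nitrogen, 1 oxygen; one five-membered aromatic ring with 1 hetero atom, one six-membered aromatic ring with 1 hetero atom), on a carbonyl carbon. Going by the values given here, the only measured step that bears on this change is the one from compound 1 to compound 2, where a 13-fold higher number from compound 1 to compound 2 (1.12 log units; beyond the scatter) came with the loss of two ring nitrogens for an oxygen and a nitrogen. Compound 3 moves part of the way back, as its incoming group again carries two nitrogens. A step back toward compound 1 is therefore expected, a 5.0-fold lower number from compound 2 to compound 3 (0.70 log units; beyond the scatter), though smaller than the full span, since the two groups are not the same. Compound 3 is estimated at 8 nM, with a range from 2.5 nM to 25 nM.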

Compound 3, half-maximal inhibitory concentration: 1800 nM
The estimate for compound 3 lay 230-fold (2.35 log units) below the measured number; the whole stated range lies below it.
By their numbers in this assay, from the lowest: compound 1; then compound 2; then compound 3.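

Counting atoms does not predict the outcome at this position. In this assay the group that enters compound 3 has the same heavy-atom and hydrogen-bond acceptor counts as the group that leaves compound 2, yet the swap brings a 45-fold higher number from compound 2 to compound 3 (1.65 log units; beyond the scatter). The headgroups of compound 1 and compound 3 each contain a five-membered aromatic ring with 2 hetero atoms, but the comparison still gives a 600-fold higher number from compound 1 to compound 3 (2.78 log units; beyond the scatter), so a shared ring type does not preserve the low number. No measurement available here accounts for these large shifts. The three headgroups leave open which feature of each bicyclic group sets its number. On these data alone, it also remains open whether a single pyridine ring or a plain phenyl group on the same carbonyl carbon would sit nearer compound 1 or compound 3.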